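The source may hold more compounds than are shown below. What is called first, only, known or untested is meant among the compounds shown, and "the series" means these compounds.

Compound 1 `C[C@@H](Cn1ccc(-c2ccc(C#N)c(Cl)c2)n1)NC(=O)c1cccc(OCC(O)CO)c1` in an ADME assay on PC-3 cells (Homo sapiens) for cytotoxicity, read by CCK-8 assay, with a stated time of 6 days (on this read-out higher numbers stand for weaker inhibition and lower numbers for stronger inhibition), gives > 30000 nM, which is a limit of the assay and not a number.
Compound 2 `C[C@@H](Cn1ccc(-c2ccc(C#N)c(Cl)c2)n1)NC(=O)c1ccccc1F` in this assay gives > 30000 nM, again a limit rather than a number.
Compound 3 `CC(Cn1ccc(-c2ccc(C#N)c(Cl)c2)n1)C(=O)Nc1cccc(C(C)O)c1` in this assay gives > 30000 nM, also a limit.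

Among the compounds with values here, compound 2 therefore stands where every measured compound stands, at the limit of > 30000 nM in this assay, at which 3 of the 3 values shown sit; no measured compound yields a number. Compound 4 `Cc1ccnc(N[C@@H](C)Cn2ccc(-c3ccc(C#N)c(Cl)c3)n2)n1` differs from compound 2 in one place: 4-methylpyrimidin-2-yl in place of (2-fluorophenyl)carbonyl on an amine nitrogen. Within the data shown here, no step between two measured compounds differing in a single place is known, so the size of this change cannot be read from comparable data. The expectation is that compound 4 stays at the limit, with a number no higher from compound 2 to compound 4 (the limit leaves the size open) being no step beyond the usual scatter. Compound 4 is estimated at 30000 nM, expected to lie between 10000 nM and 100000 nM.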

Compound 4, half-maximal inhibitory concentration: > 30000 nM
Compound 4 ended at the assay's limit; the forecaster's own chance of this, stated with the estimate: 85%; the middle value sits exactly at the limit.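

Within the data shown here, compound 2 and compound 4 both end at a limit of the assay rather than a number, so no step between them can be read. The compounds shown leave open which change, if any, would give a readable number: the limit of > 30000 nM in this assay, at which 4 of the 4 values shown sit.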